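A Methyl Added Where Compound 3 Carries Hydrogen

A few compounds are considered here, and "the series" means these few. Any claim that something is new, unique, unknown or untested is made for them only; others in the source may bear on it.

Among the measured compounds shown here, the three compounds measured so far share one core and were all tested in a toxicity assay on RMS13 cells (Homo sapiens) for inhibition, with a stated time of 24 h; a higher number here means a weaker inhibitor of growth, a lower number a stronger inhibitor of growth. Compound 1 `CC1=C(C(=O)OCc2ccccc2)C(c2ccc(-c3ccccc3)cc2)N(CCCCCC(=O)O)C(=S)N1` gives 110000 nM. Compound 2 `CC1=C(C(=O)OCc2ccccc2)C(c2ccc(-c3ccccc3C)cc2)NC(=O)N1CCCCCc1nnn[nH]1` gives 100000 nM. Compound 3 `CC1=C(C(=O)OCc2ccccc2)C(c2ccc(-c3ccccc3)cc2)N(Cc2ccc(-c3nnn[nH]3)cc2)C(=S)N1` gives 72000 nM, the lowest of the three numbers, yet its distance to compound 2 and to compound 1 each lies within the scatter, so no real difference among the three can be claimed. For the measured compounds named here, the only step between measured compounds that differ in a single place, a 1.5-fold lower number from compound 1 to compound 3 (0.18 log units; within the scatter), concerns the saturated chain carbon bound to an amide-type nitrogen in a ring and says nothing about an aromatic carbon.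

Compound 4 `CC1=C(C(=O)OCc2ccccc2)C(c2ccc(-c3ccccc3C)cc2)N(Cc2ccc(-c3nnn[nH]3)cc2)C(=S)N1` differs from compound 3 by methyl in place of hydrogen on an aromatic carbon. Going by the values given here, no measured step bears directly on this change. Compound 2 also carries a 2-methylphenyl group, but it differs from compound 3 in more than one place; in this assay compound 2 gives 100000 nM, and this number only weakly hints that such a methyl leaves the number where it was. The step of a 1.0-fold higher number from compound 3 to compound 4 (0.02 log units; within the scatter) is therefore expected to stay within the scatter, with no direction. Compound 4 is estimated at 75000 nM, with a range from 30000 nM to 180000 nM.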

Compound 4, concentration for 50% growth inhibition: 62000 nM
Compound 4: the middle estimate sits 1.2-fold (0.08 log units) above what was measured, and the stated range covers the measured number.
By their numbers in this assay, from the lowest: compounds 4, 3, 2 and 1 (each within the scatter of the next).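

Methyl in place of hydrogen on this aromatic carbon, ortho to a large group, now has a direct reading in this assay and the change of phenyl to 2-methylphenyl gives a 1.2-fold lower number from compound 3 to compound 4 (0.06 log units; within the scatter) with nothing else differing between the two structures. Compound 2 also carries the 2-methylphenyl group but differs from compound 3 in more than one place, so it could only hint at what this single pair now shows: at this position, the added methyl leaves the two numbers within the scatter of each other, and no direction can be claimed. No accompanying measurement offers an explanation for this outcome.

The compounds shown leave open whether other groups on this same carbon, such as chlorine, methoxy, an amine or a carboxylic acid, would also stay within the scatter, or whether any of them would produce a clear step in either direction. They also leave open how a methyl on a different carbon of this ring would read, and whether this methyl would read the same in a compound carrying the carboxylic acid chain of compound 1 instead of the tetrazole-bearing group.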